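The compounds below may be only part of what the source reports. "The series", "measured", "known", "first", "only" and "open" are said of these compounds alone.

Measured so far in a physicochemical assay for lipophilicity, read by HPLC, in phosphate buffer, measured as octanol-water partition, at pH 7.4, tested at 100 uM; on this read-out lower numbers stand for lower lipophilicity and higher numbers for higher lipophilicity:

Compound 1 `Cc1cc(OCCCS(C)(=O)=O)cc(C)c1-c1cccc(CNc2ccc(OCC(=O)O)c(F)c2)c1` — in this assay compound 1 gives 1.73
Compound 2 `O=C(O)COc1ccc(NCc2cccc(-c3ccccc3Cl)c2)cc1F` — in this assay compound 2 gives 2.71

Compound 2 holds the higher of the two numbers recorded so far in this assay. Its nearest neighbour is compound 1, whose value lies lower by a gap that is beyond the usual scatter; the two structures differ in more than one place, so nothing more is read into that gap than what the two values show.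

Compound 3 `Cc1ccc(-c2cccc(CNc3ccc(OCC(=O)O)c(F)c3)c2)c(Cl)c1` has not yet been measured in this assay. Relative to compound 2 the change is small: methyl in place of hydrogen on an aromatic carbon. Among the compounds with values here, no pair of measured compounds in this set differs by a change of this kind, so there is no measured step to lean on.

In this assay the estimated step is a number 0.44 log units higher from compound 2 to compound 3 (beyond the scatter), a modest move upward. For compound 3 the expected value in this assay is 3.15, with an estimated range from 2.75 to 3.55.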

Compound 3, distribution coefficient: 3.24
For compound 3 the middle estimate is 0.09 log units below the measured one; measured number inside the range.
By their numbers in this assay, from the lowest: compound 1; then compound 2; then compound 3.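

In this assay, the only single-place change among the compounds shown is the move from 2-chlorophenyl to 2-chloro-4-methylphenyl, which reads as a number 0.53 log units higher from compound 2 to compound 3 (beyond the scatter). It shows that this position, an aromatic carbon meta to a chloro group and para to a large group, is not silent in this read-out: methyl in place of hydrogen, a change of 1 heavy atom with no hydrogen-bond donors or acceptors and no net charge, gives a step beyond the scatter, whereas the gap between compound 1 and compound 2 spans more than one place and could not be tied to any single position. Nothing at hand bears on why the step has this size.

This remains a single step at a single position, so the compounds shown leave open whether ethyl, methoxy or an amine in place of the methyl would move the read-out in the same direction or by a similar size. Also open, on these data alone, is whether methyl at this position gives a comparable step without the chloro group, or on the ring of compound 1 that carries the two methyl groups.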